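This account rests on a few compounds, and the source may have more. Where it says the series, first, only, none or still open, it means among the compounds named here.

Compound 3, with the structure `Cc1cccc(NC(=O)CSC(=S)N[C@H]2CCOC2=O)c1`, sits at the edge of what the assay can report: in a functional assay on SMMC-7721 cells (Homo sapiens) for cytotoxicity, read by MTT assay, with a stated time of 72 h (on this read-out lower numbers stand for stronger inhibition and higher numbers for weaker inhibition), compound 3 gives > 128000 nM, which is a limit rather than a number. Compound 1, with the structure `O=C(CSC(=S)N[C@H]1CCOC1=O)Nc1ccc(Cl)cc1`, is in the same position, since in this assay compound 1 gives > 128000 nM, again a limit. Within the data shown here, the only full number among the three belongs to compound 2, the structure `Cc1cccc(NC(=O)CSC(=S)N[C@H]2CCOC2=O)c1C`, which in this assay gives 42200 nM. Two of the three known results therefore stop at the limit of > 128000 nM in this assay, at which 2 of the 3 values shown sit. The change from compound 2 to compound 3 is a single aromatic methyl replaced by hydrogen, and it carries an at least 3.0-fold higher number from compound 2 to compound 3 (0.48 log units; beyond the scatter). The exchange of the aromatic ring substituent from compound 1 to compound 3 is a step that the two limits leave unreadable from compound 1 to compound 3.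

Compound 4, with the structure `O=C(CSC(=S)N[C@H]1CCOC1=O)Nc1cccc([N+](=O)[O-])c1`, takes compound 3 one step further: nitro in place of methyl on an aromatic carbon. Among the measured compounds shown here, no known step here involves a nitro group, so the closest guidance is that compound 3 already stands at the limit and the one readable change, the loss of a methyl, moved the number upward. For compound 4 the expected outcome in this assay is therefore 110000 nM, within a range of 35000 nM to 350000 nM, most likely reported only as a limit, and the expected step from compound 3 to compound 4 is an at least 1.1-fold lower number from compound 3 to compound 4 (0.06 log units; that floor lies within the scatter).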

Compound 4, half-maximal inhibitory concentration: > 128000 nM
Compound 4 gave a limit, no number; the forecaster's own chance of this, stated with the estimate: 60%; middle value at least 1.1-fold (0.06 log units) from the limit.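

Compound 3 and compound 4 both end in a limit rather than a number in this assay, so the step from methyl to nitro cannot be read: the limit of > 128000 nM in this assay, at which 3 of the 4 values shown sit. The compounds shown leave open what the true values of compound 1, compound 3 and compound 4 are, and so how the groups on their aromatic rings compare.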